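A few compounds are considered here, and "the series" means these few. Any claim that something is new, unique, unknown or untested is made for them only; others in the source may bear on it.

Going by the values given here, compound 3 `Cc1ccc2c(c1)CC(CCN(C)C)=C2C(C)c1ccccn1` gives 1450 nM in an assay on CHO-K1 cells for binding affinity to muscarinic acetylcholine receptor M5 (Homo sapiens) (on this read-out lower numbers stand for stronger inhibition and higher numbers for weaker inhibition), the second highest of the three numbers measured so far; compound 2 `CC(C1=C(CCN(C)C)Cc2ccc(Cl)cc21)c1ccccn1` gives 912 nM and compound 1 `COc1ccc2c(c1)C(C(C)c1ccccn1)=C(CCN(C)C)C2` gives 8910 nM. Compound 4 `COc1ccc2c(c1)CC(CCN(C)C)=C2C(C)c1ccccn1` differs from compound 3 by methoxy in place of methyl on an aromatic carbon. Among the compounds with values here, the one measured step that touches a methoxy group is a 9.8-fold lower number from compound 1 to compound 2 (0.99 log units; beyond the scatter), and compound 1, which carries the methoxy, shows the highest number of the set. Within the data shown here, that step is not the same exchange, and no measured pair sets methyl directly against methoxy. Even so, a move to methoxy is expected to raise the number, and compound 4 is estimated at 4000 nM, in a range from 1500 nM to 12000 nM, an expected step of a 2.8-fold higher number from compound 3 to compound 4 (0.44 log units; beyond the scatter).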

Compound 4, inhibition constant: 6030 nM
Compound 4: the middle estimate sits 1.5-fold (0.18 log units) below what was measured; the measured number falls inside the stated range.
By their numbers in this assay, from the lowest: compounds 2 and 3 (each within the scatter of the next); then compounds 4 and 1 (each within the scatter of the next).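

In this assay, going by these compounds alone, the step of a 4.2-fold higher number from compound 3 to compound 4 (0.62 log units; beyond the scatter) gives the first direct comparison of methoxy with methyl on this aromatic carbon, and it goes against methoxy. Earlier, methoxy had been set only against chloro, on the core of compound 1, so methoxy now gives the higher number against two different groups and on two different cores. No available evidence explains this difference.

On these data alone, what a hydroxyl or ethoxy group would give on this carbon remains open, so it is unclear whether the trend continues beyond these groups.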